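A few compounds are considered here, and "the series" means these few. Any claim that something is new, unique, unknown or untested is made for them only; others in the source may bear on it.

Of the compounds shown here, three have so far been measured in a functional assay on HCT-116 cells (Homo sapiens) for inhibition, read by luminescence and resazurin assay, with a stated time of 3 days; on this read-out lower numbers stand for stronger inhibition and higher numbers for weaker inhibition. Compound 1 `CCCNc1nc(NCc2ccc(NC(=O)c3ccc(F)cc3)cc2)c2ccccc2n1` gives 1700 nM, the lowest of the three numbers. Compound 2 `CNc1nc(NCc2ccc(NS(=O)(=O)c3ccc(F)cc3)cc2)c2ccccc2n1` gives 5300 nM, and compound 3 `Cc1ccc(S(=O)(=O)Nc2ccc(CNc3nc(N(C)C)nc4ccccc34)cc2)cc1` gives 11000 nM, both of them higher than compound 1 by more than the usual scatter. Compound 4 `CN1CCN(c2nc(NCc3ccc(NC(=O)c4ccc(F)cc4)cc3)c3ccccc3n2)CC1` has not yet been measured. It differs from compound 1 in one place: 4-methylpiperazin-1-yl in place of propylamino on an aromatic carbon, on an aromatic carbon of the shared core that sits between two ring nitrogen atoms. For the measured compounds named here, no measured pair differs in only this place, so the size of the step is open. A modest weakening, or no change beyond the scatter, is expected, as the estimated step of a 1.5-fold higher number from compound 1 to compound 4 (0.17 log units; within the scatter) shows. Compound 4 is therefore estimated at 2500 nM, within a range of 800 nM to 8000 nM.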

Compound 4, half-maximal inhibitory concentration: 1800 nM
Compound 4: middle estimate off by 1.4-fold (0.14 log units), on the high side, and the stated range covers the measured number.
By their numbers in this assay, from the lowest: compounds 1 and 4 (each within the scatter of the next); then compound 2; then compound 3.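

In this assay, putting 4-methylpiperazin-1-yl in place of propylamino on the shared core gives a 1.1-fold higher number from compound 1 to compound 4 (0.02 log units; within the scatter) and so stays within the scatter. The entering group brings a six-membered non-aromatic ring and 0 hydrogen-bond donors, where propylamino has 1 hydrogen-bond donor, so for this pair the position between the two ring nitrogen atoms accepts both groups with no shift beyond the scatter.

On these data alone, whether an unsubstituted amino group or a morpholine ring would read the same at this position stays open. Nothing shown here tells why these two groups read alike.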